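This account rests on a few compounds, and the source may have more. Where it says the series, first, only, none or still open, it means among the compounds named here.

Compound 1, `O=C(COc1ccc(C(=O)/C=C/c2ccc(Cl)cc2Cl)cc1)N[C@H]1CCOC1=O`, in a functional assay on MGC-803 cells (Homo sapiens) for antiproliferative activity, read by MTT assay, with a stated time of 72 h (a higher number here means a weaker inhibitor, a lower number a stronger inhibitor), gives 26500 nM.
Compound 2, `COc1ccccc1/C=C/C(=O)c1ccc(OCC(=O)N[C@H]2CCOC2=O)cc1`, in this assay gives 39400 nM.
Compound 3, `O=C(COc1ccc(C(=O)/C=C/c2ccc(F)cc2)cc1)N[C@H]1CCOC1=O`, in this assay gives only a limit of the assay, > 64000 nM.

Compound 3 therefore has no number of its own; it stands at the limit of > 64000 nM in this assay, at which 1 of the 3 values shown sits, so that only the direction away from compound 1 and compound 2 is known. The two measured steps that reach it both exchange the aryl group on the double-bonded chain carbon: an at least 2.4-fold higher number from compound 1 to compound 3 (0.38 log units; beyond the scatter), and an at least 1.6-fold higher number from compound 2 to compound 3 (0.21 log units; that floor lies within the scatter). The third step among the measured compounds, a 1.5-fold higher number from compound 1 to compound 2 (0.17 log units; within the scatter), shows that the 2,4-dichlorophenyl and 2-methoxyphenyl analogues sit close to each other.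

Compound 4, `O=C(COc1ccc(C(=O)/C=C/c2ccccc2)cc1)N[C@H]1CCOC1=O`, differs from compound 3 by hydrogen in place of fluoro on an aromatic carbon. Going by the values given here, no measured step removes a single substituent from the aryl ring, so the expectation rests on the position of compound 3 alone, which in this assay already gives > 64000 nM. Compound 4 is expected to remain in the same weak region, with an expected step that the limit leaves unreadable from compound 3 to compound 4 that is not beyond the scatter. Compound 4 is therefore estimated at 70000 nM, with a range from 30000 nM to 160000 nM, and it is likely that the assay again reports only a limit.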

Compound 4, half-maximal inhibitory concentration: > 64000 nM
Compound 4 ended at the assay's limit; the forecaster's own chance of this, stated with the estimate: 65%; the middle value does not contradict the limit.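

Compound 4, with hydrogen in place of fluoro on the aromatic carbon, stops at the same limit of the assay as compound 3, and neither value is a number: the limit of > 64000 nM in this assay, at which 2 of the 4 values shown sit. The step between these two cannot be read, so the loss of the fluoro group has no measurable size here, and what compound 4 adds is that a phenyl group with no substituent also fails to give a number in this assay. The two readable steps are an at least 2.4-fold higher number from compound 1 to compound 4 (0.38 log units; beyond the scatter) and an at least 1.6-fold higher number from compound 2 to compound 4 (0.21 log units; that floor lies within the scatter), so among these four compounds the 2,4-dichlorophenyl and 2-methoxyphenyl analogues give numbers, while the 4-fluorophenyl and phenyl analogues stop at the limit.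

As far as these compounds go, how far compound 3 and compound 4 lie beyond the limit stays open, so the fluoro and hydrogen analogues cannot be placed in any order. From the compounds shown here alone, it also remains open whether an amine or a carboxylic acid on the phenyl ring, or a longer chain in place of the ethenyl link, would bring the series back to a measurable value.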